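Methylamino for Methylsulfanyl: Expectation at the Assay Limit

A few compounds are considered here, and "the series" means these few. Any claim that something is new, unique, unknown or untested is made for them only; others in the source may bear on it.

Compound 1, `C[C@H]1O[C@@H](n2c(Br)nc3cc(Cl)c(Cl)cc32)[C@H](O)[C@@H]1O`: > 100000 nM in a functional assay on KB cells (Homo sapiens) for inhibition; on this read-out higher numbers stand for weaker inhibition and lower numbers for stronger inhibition
Compound 2, `CSc1nc2cc(Cl)c(Cl)cc2n1[C@@H]1O[C@H](CO)[C@@H](O)[C@H]1O`: > 100000 nM
Compound 3, `CSc1nc2cc(Cl)c(Cl)cc2n1[C@@H]1O[C@@H](CO)[C@@H](O)[C@H]1O`: > 100000 nM

Every value shown for this assay is a limit rather than a number. Compound 2 stands at that limit, and so do its two companions, as the limit of > 100000 nM in this assay, at which 3 of the 3 values shown sit, records. Within the data shown here, the only measured step, a step that the two limits leave unreadable from compound 2 to compound 3, cannot be read in size since both of its ends rest on the same limit (the limit of > 100000 nM in this assay, at which 3 of the 3 values shown sit); all that distinguishes the pair is the fact that compounds 2 and 3 differ only in the configuration as drawn. Compound 4, `CNc1nc2cc(Cl)c(Cl)cc2n1[C@@H]1O[C@H](CO)[C@@H](O)[C@H]1O`, differs from compound 2 by methylamino in place of methylsulfanyl on an aromatic carbon. Among the measured compounds shown here, no measured step bears on this exchange, so nothing in the data predicts a change beyond the scatter. Compound 4 is therefore expected to give 100000 nM in this assay, with a range from 30000 nM to 300000 nM. This amounts to an expected step of a number no higher from compound 2 to compound 4 (the limit leaves the size open).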

Compound 4, half-maximal inhibitory concentration: > 100000 nM
Compound 4: no number, only a limit; the forecaster's own chance of this, stated with the estimate: 80%; the middle value lies on the limit itself.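

Compound 4 also rests on a limit, so the step from compound 2 to compound 4 cannot be read in this assay: the limit of > 100000 nM in this assay, at which 4 of the 4 values shown sit.

The compounds shown leave open whether methylamino in place of methylsulfanyl changes inhibition at all; none of them gives a number.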